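Shrinking the alkoxy ring on the shared core

The compounds below may be only part of what the source reports. "The series", "measured", "known", "first", "only" and "open" are said of these compounds alone.

Compound 1, `Cc1ccc(OCC2CCCC2)cc1-c1cccc(COc2ccc(OCC(=O)O)c(F)c2)c1`, gives 490 nM in a functional assay on CHO cells for agonist activity at Free fatty acid receptor 1 (Homo sapiens), read by FLIPR and calcium flux; on this read-out lower numbers stand for an effect already at smaller amounts and higher numbers for an effect only at larger amounts of compound.
Compound 2, `Cc1ccc(OCC2CCC2)cc1-c1cccc(COc2ccc(OCC(=O)O)c(F)c2)c1`, gives 1530 nM in this assay.

Among the compounds with values here, compound 2 stands at the higher of the two numbers measured so far; its nearest neighbour is compound 1, and the step of a 3.1-fold higher number from compound 1 to compound 2 (0.49 log units; beyond the scatter) is the only one known. Compound 3, `COc1ccc(C)c(-c2cccc(COc3ccc(OCC(=O)O)c(F)c3)c2)c1`, takes the same direction one stage further: hydrogen in place of cyclobutyl on a saturated chain carbon bound to an oxygen on an aromatic ring. Within the data shown here, the single measured step that bears on this change is a 3.1-fold higher number from compound 1 to compound 2 (0.49 log units; beyond the scatter), where the smaller ring already brought a modest rise in the number. Among the measured compounds shown here, removing the ring altogether is judged to be a larger change of the same kind, so a further rise in this assay is expected for compound 3, most likely beyond the usual scatter, though no measured compound shows how steep it will be. Compound 3 is therefore estimated at 5500 nM in this assay, with a range from 2000 nM to 15000 nM, which would mean a step of a 3.6-fold higher number from compound 2 to compound 3 (0.56 log units; beyond the scatter).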

Compound 3, half-maximal effective concentration: 260 nM
Estimate against measurement, compound 3: 21-fold (1.33 log units) above; the measured number lies below the stated range.
By their numbers in this assay, from the lowest: compounds 3 and 1 (each within the scatter of the next); then compound 2.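

At this place, on a saturated chain carbon bound to an oxygen on an aromatic ring, the number in this assay does not keep rising as the ring is cut away: a 5.9-fold lower number from compound 2 to compound 3 (0.77 log units; beyond the scatter) reverses the earlier rise once cyclobutyl gives way to hydrogen. The step of a 1.9-fold lower number from compound 1 to compound 3 (0.28 log units; within the scatter) gives no order between cyclopentylmethoxy and methoxy, so among the three compounds only cyclobutylmethoxy stands apart, and a ring at this place is not required to reach the level of compound 1. Nothing measured here bears on what lies behind this turn in the numbers.

The compounds shown leave open how an ethoxy group, a longer chain such as butoxy, or a cyclohexylmethoxy group would read at this place. They also leave open whether compound 2 is a lone exception or part of a wider pattern that an amine or an ether in the chain might help to show.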